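Shortening the side chain: from isopropylphenyl to benzyl

This account rests on a few compounds, and the source may have more. Where it says the series, first, only, none or still open, it means among the compounds named here.

Measured so far:
compound 1, `CC(C)c1ccc(C[C@H]2COc3cc(-c4cc(F)ccc4C(=O)O)ccc3[C@@H]2O)cc1`: 210 nM
compound 2, `O=C(O)c1ccc(F)cc1-c1ccc2c(c1)OC[C@H](Cc1ccc(-c3ccccc3)cc1)[C@H]2O`: 56 nM; 5 nM (2 entries)

Among the compounds with values here, in a functional assay with leukotriene B4 receptor (Homo sapiens) as the target (on this read-out higher numbers stand for weaker inhibition and lower numbers for stronger inhibition), compound 1 gives 210 nM; this is its only number there, with a further entry that gives no single number. Compound 2 gives 56 nM; 5 nM (2 entries) in this assay, and its repeated entries the several entries of compound 2 in this assay, 56 nM; 5 nM (2 entries) show how far such readings can spread.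

Compound 3, `O=C(O)c1ccc(F)cc1-c1ccc2c(c1)OC[C@H](CCc1ccccc1)[C@H]2O`, has not yet been measured in this assay. It differs from compound 1 by benzyl in place of 4-isopropylphenyl on a saturated chain carbon bound to a saturated ring carbon. Within the data shown here, no measured pair shows this exact change, so the size of the step is an expectation rather than a reading. The change removes carbon from the side chain, and compound 2, which carries a larger biphenyl group, reads 56 nM; 5 nM (2 entries), so a somewhat weaker result is expected for the smaller compound 3, with the step of a 2.9-fold higher number from compound 1 to compound 3 (0.46 log units; beyond the scatter).

Compound 3 is estimated at 600 nM, within 150 nM to 2500 nM.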

Compound 3, half-maximal inhibitory concentration: 32 nM
For compound 3 the middle estimate is 19-fold (1.27 log units) above the measured one; measured number outside the range, below it.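

At this position, on a saturated chain carbon bound to a saturated ring carbon, fewer side-chain carbons do not cost inhibition in this assay: benzyl in place of 4-isopropylphenyl gives a 6.6-fold lower number from compound 1 to compound 3 (0.82 log units; beyond the scatter). Side-chain size alone therefore does not order these readings, as compound 3, with the smaller group, and compound 2, with its larger biphenyl group at 56 nM; 5 nM (2 entries), both read below compound 1. Comparisons with compound 2 need care, as single readings of one compound can differ widely: the several entries of compound 2 in this assay, 56 nM; 5 nM (2 entries)

The change removes the isopropyl group and also alters how the phenyl ring is attached to the chain, and the compounds shown do not separate these two effects. Also open, as far as these compounds go, is how a longer chain such as phenylpropyl, or an amine on the phenyl ring, would read.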